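Compound 1 to compound 4: trimming the ether chain

The source may report more compounds than this note shows. Statements on the series, on what has been measured and on what is new or still open speak of the compounds shown alone.

Measured so far in a functional assay on A549 cells (Homo sapiens) for cytotoxicity, read by MTT assay, with a stated time of 72 h (on this read-out lower numbers stand for stronger inhibition and higher numbers for weaker inhibition), and compared below
compound 1 `COc1cc(/C=C/C=O)cc(OC)c1OC/C=C(\C)CCC=C(C)C` gives 71000 nM
compound 2 `CC(C)=CCOc1ccc(C(=O)/C=C/c2ccccc2)c(O)c1` gives 54000 nM
compound 3 `CC(C)=CCC/C(C)=C/COc1ccc(/C=C/C(=O)O)cc1` gives > 100000 nM as a limit

Going by the values given here, compound 1 lies within the scatter of compound 2, and these are the only two numbers available. Compound 3 gives only a limit, not a number.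

Compound 4 `COc1cc(/C=C/C=O)cc(OC)c1OCC=C(C)C` has not yet been measured. The change from compound 1 to compound 4 is hydrogen in place of 3-methylbut-2-en-1-yl on a saturated chain carbon bound to a double-bonded chain carbon and puts hydrogen in place of 3-methylbut-2-en-1-yl on a saturated chain carbon bound to a double-bonded chain carbon. Among the compounds with values here, no measured pair differs in one place only, so the series offers no direct guide. Compound 2, which has a different core, also carries a 3-methylbut-2-en-1-yl group on oxygen and gives 54000 nM in the same assay range as compound 1. On that weak basis, no step beyond the scatter is expected in this assay for this change. The expected change is a 1.1-fold higher number from compound 1 to compound 4 (0.05 log units; within the scatter) and it stays within the scatter. A result reported only as a limit remains possible. For compound 4 the estimated value is 80000 nM with an expected range from 40000 nM to 160000 nM as the working figure.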

Compound 4, half-maximal inhibitory concentration: 68000 nM
Compound 4: middle estimate off by 1.2-fold (0.07 log units), on the high side; the measured number falls inside the stated range.
By their numbers in this assay, from the lowest: compounds 2, 4 and 1 (each within the scatter of the next). At a limit, above all of these: compound 3.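

In this assay, the series now has its first pair differing in one place, and hydrogen in place of 3-methylbut-2-en-1-yl gives a 1.0-fold lower number from compound 1 to compound 4 (0.02 log units; within the scatter). On a saturated chain carbon bound to a double-bonded chain carbon, losing these 5 heavy atoms, with their double bond, therefore produces no step beyond the scatter on the shared core. Going by these compounds alone, this single pair gives a first reading at this position, which the earlier compounds could not give, but it does not extend to other changes there.

Going by these compounds, compound 3 remains a limit rather than a number, and it offers no comparison in one place: the limit of > 100000 nM in this assay, at which 1 of the 4 values shown sits. Whether an amine in place of the 3-methylbut-2-en-1-yl on that carbon would produce a step beyond the scatter remains open.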